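Sulfonyl piperazine anilides: step from compound 2 to compound 4

This account rests on a few compounds, and the source may have more. Where it says the series, first, only, none or still open, it means among the compounds named here.

Three compounds of this series have numbers in an assay on HEK293 cells for inhibition of potassium channel subfamily T member 1 (Homo sapiens), read by thallium flux (on this read-out lower numbers stand for stronger inhibition and higher numbers for weaker inhibition), so far. Compound 1 `COc1ccc(Cl)cc1NC(=O)CN(C)CCN(C)S(=O)(=O)N1CCC(C)CC1` stops at the assay limit, giving > 10000 nM in this assay. Compound 2 `CCCC1CCN(C(=O)N2CCN(S(=O)(=O)N3CCN(CC(=O)Nc4cc(Cl)ccc4OC)CC3)CC2)CC1` likewise stops at the limit, giving > 10000 nM in this assay. Compound 3 `CC1CCN(S(=O)(=O)N2CCN(CC(=O)Nc3cc(Cl)ccc3OC(C)C)CC2)CC1` gives a number, 5100 nM in this assay. Compound 2 therefore stands at the limit, and the limit of > 10000 nM in this assay, at which 2 of the 3 values shown sit, shows that two of the three values shown sit there. Among the compounds with values here, no step between measured compounds that differ in one place is available.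

Compound 4 `COc1ccc(Cl)cc1NC(=O)CN1CCN(S(=O)(=O)N2CCN(S(=O)(=O)c3ccc(Cl)cc3)CC2)CC1` is not yet measured. It differs from compound 2 by (4-chlorophenyl)sulfonyl in place of (4-propylpiperidin-1-yl)carbonyl on an amine nitrogen in a ring. Compound 3 reaches only 5100 nM in this assay. No large movement is expected from this change, and the step is estimated as an at least 1.1-fold lower number from compound 2 to compound 4 (0.04 log units; that floor lies within the scatter), likely within the scatter. Compound 4 is expected to give about 9000 nM in this assay, with a range from 3000 nM to 30000 nM, and a fair chance that only a limit is reported.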

Compound 4, half-maximal inhibitory concentration: 2300 nM
Compound 4: middle estimate off by 3.9-fold (0.59 log units), on the high side; the whole stated range lies above it.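

On the amine nitrogen in a ring, the group carried there does move the read-out in this assay: (4-chlorophenyl)sulfonyl in place of (4-propylpiperidin-1-yl)carbonyl gives an at least 4.3-fold lower number from compound 2 to compound 4 (0.63 log units; beyond the scatter). Within the data shown here, with this change the position yields the first readable step, and compound 4 gives a number, 2300 nM, rather than a limit. The step is only a bound, because compound 2 is a limit and not a number: the limit of > 10000 nM in this assay, at which 2 of the 4 values shown sit.

The compounds shown leave open whether the change in read-out follows the sulfonyl link or the 4-chlorophenyl ring, which a benzoyl or a plain phenylsulfonyl group at this place would help to separate. On these data alone, how a small methanesulfonyl group or the free ring amine would read at the same nitrogen also remains open.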